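The compounds below may be only part of what the source reports. "The series", "measured", "known", "first", "only" and "open" are said of these compounds alone.

Measured compounds:
Compound 1, `N/C(=N\NC(=S)N1CCCC1)c1ccc(F)cn1`, gives 72.2%.
Compound 2, `N/C(=N\NC(=S)N1CCSCC1)c1ccccn1`, gives 37.2%.

Of the compounds shown here, two have been measured in a functional assay on A-431 cells (Homo sapiens) for cytotoxicity, read by MTT assay, with a stated time of 72 h, tested at 3 uM; on this read-out lower numbers stand for less inhibition of growth and higher numbers for more inhibition of growth at the one concentration tested. Compound 1 gives 72.2%. Compound 2 gives 37.2%, the lower of the two numbers, and the gap to compound 1 lies beyond the scatter. Going by the values given here, the two differ in two places at once, so their values show only that the pair as a whole is far apart, not what either change contributes on its own.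

Compound 3, `N/C(=N\NC(=S)N1CCSCC1)c1ccc(F)cn1`, has not yet been measured in this assay. It keeps the core of compound 2 and carries one change: fluoro in place of hydrogen on an aromatic carbon. Among the compounds with values here, no step between measured compounds isolates this change. Within the data shown here, the only pointer is that compound 1, which also carries fluoro on its six-membered aromatic ring, gives 72.2%, while compound 2 gives 37.2%. Since the other difference between those two is not separated out, only a moderate rise is expected, not the whole gap.

The estimate for compound 3 is therefore 50%, with a range from 30% to 70%. This estimate means an expected step of a number 12.8 percentage points higher from compound 2 to compound 3 (beyond the scatter), modest in size and upward, possibly within the scatter.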

Compound 3, percent growth inhibition at one concentration: 61.2%
Beside the measured number, compound 3's estimate is 11.2 percentage points below it; low and high end bracket the measured number.
By their numbers in this assay, from the lowest: compound 2; then compound 3; then compound 1.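

In this assay, the position two atoms from the ring nitrogen and para to a large group now has a step of its own: with thiomorpholin-4-yl held fixed, fluoro in place of hydrogen gives a number 24 percentage points higher from compound 2 to compound 3 (beyond the scatter), so this single change on the aromatic carbon moves the read-out beyond the scatter. Going by these compounds alone, the second step isolates the other change for the first time: with fluoro held fixed, thiomorpholin-4-yl in place of pyrrolidin-1-yl on the thiocarbonyl carbon gives a number 11 percentage points lower from compound 1 to compound 3 (beyond the scatter), so each of the two places now has its own reading, and each step lies beyond the scatter. Nothing at hand speaks to why either change has the effect it does.

The compounds shown leave open whether fluoro in place of hydrogen gives a step of similar size when pyrrolidin-1-yl sits on the thiocarbonyl carbon, since the step is seen only with thiomorpholin-4-yl. Within the data shown here, they also leave open whether the same position would respond in a similar way to a chlorine atom or a methoxy group, as fluoro is the only group other than hydrogen seen there.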